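Adding a Methoxy Group to the Phenyl Ring

The source may report more compounds than this note shows. Statements on the series, on what has been measured and on what is new or still open speak of the compounds shown alone.

Of the compounds shown here, two sharing one core have been measured. Compound 1 `COc1cc(/C=C/C(=O)c2cccc(-n3cc(-c4ccccc4)[nH]c3=O)c2)ccc1O` carries a single methoxy group and a hydroxyl on its cinnamoyl side; compound 2 `COc1cc(/C=C/C(=O)c2cccc(-n3cc(-c4ccccc4)[nH]c3=O)c2)cc(OC)c1OC` carries three methoxy groups there instead. In a functional assay on OVCAR-5 cells (Homo sapiens) for inhibition (on this read-out higher numbers stand for weaker inhibition of growth and lower numbers for stronger inhibition of growth), compound 2 gives 1880 nM, and in this assay compound 1 gives 2040 nM, a number that sits within the usual scatter of that of compound 2, so the two cannot be told apart.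

Compound 3 `COc1ccc(-c2cn(-c3cccc(C(=O)/C=C/c4cc(OC)c(OC)c(OC)c4)c3)c(=O)[nH]2)cc1` differs from compound 2 in one place: methoxy in place of hydrogen on an aromatic carbon. For the measured compounds named here, no measured pair of compounds shows what such a change does here, so there is nothing to lean on beyond the structural change itself. The expectation is a step from compound 2 to compound 3 of a 1.1-fold lower number from compound 2 to compound 3 (0.04 log units; within the scatter), that is, no change beyond the scatter. Compound 3 is therefore estimated at 1700 nM, with a likely range from 700 nM to 4500 nM.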

Compound 3, concentration for 50% growth inhibition: 2640 nM
Beside the measured number, compound 3's estimate is 1.6-fold (0.19 log units) below it, and the stated range covers the measured number.
By their numbers in this assay, from the lowest: compounds 2, 1 and 3 (each within the scatter of the next).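

For the compounds shown here, this is the first measured change on this phenyl ring of the shared core. Going from phenyl to 4-methoxyphenyl, with the methoxy on an aromatic carbon para to a large group, gives a 1.4-fold higher number from compound 2 to compound 3 (0.15 log units; within the scatter) in this assay, so adding this group leaves growth inhibition indistinguishable from that of the unsubstituted ring. Nothing in the data at hand offers a reason for this result.

A single methoxy group cannot show how this position responds in general, and an amine, a carboxylic acid or a longer chain in its place could behave quite differently. Going by these compounds, it also remains open whether the same phenyl to 4-methoxyphenyl change would do as little on the core of compound 1, which carries a hydroxyl and one methoxy group on its cinnamoyl side.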